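The compounds below may be only part of what the source reports. "The series", "measured", "known", "first", "only" and "open" are said of these compounds alone.

Compound 3 `O=C(CCc1ccc(C(F)(F)F)cc1)Nc1ccc2nc(N3CC4CCC3C4)ccc2c1` gives 1 nM in an assay on isolated protein for displacement of a labelled ligand from melanin-concentrating hormone receptor 1 (Homo sapiens) (a higher number here means a weaker inhibitor, a lower number a stronger inhibitor), the lowest number of the three measured compounds. Compound 1 `O=C(CCc1ccc(C(F)(F)F)cc1)Nc1ccc2nc(N3CCCCC3)ccc2c1` gives 12 nM in this assay, and compound 2 `CN(C)c1ccc2cc(NC(=O)CCc3ccc(C(F)(F)F)cc3)ccc2n1` gives 13 nM; between those two the change was a 1.1-fold higher number from compound 1 to compound 2 (0.03 log units; within the scatter). Compound 3 is set apart from both by a 12-fold lower number from compound 1 to compound 3 (1.08 log units; beyond the scatter) and by a 13-fold lower number from compound 2 to compound 3 (1.11 log units; beyond the scatter).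

Compound 4 `Nc1ccc2cc(NC(=O)CCc3ccc(C(F)(F)F)cc3)ccc2n1` has not yet been measured. It differs from compound 3 at the same place on the core that those two steps concerned: one nitrogen atom in place of a group of 7 heavy atoms (6 carbon, 1 nitrogen; one five-membered non-aromatic ring of carbon only, one five-membered non-aromatic ring with 1 hetero atom), on an aromatic carbon

Both steps that bear on this position were large and ran the same way, with a 12-fold lower number from compound 1 to compound 3 (1.08 log units; beyond the scatter) and a 13-fold lower number from compound 2 to compound 3 (1.11 log units; beyond the scatter) each lowering the number on arrival at the bicyclic group. Compound 4 moves in the opposite direction and goes past the dimethylamino of compound 2 to a single nitrogen atom, so a step of comparable size upward is expected, a 30-fold higher number from compound 3 to compound 4 (1.48 log units; beyond the scatter). Compound 4 is therefore estimated at 30 nM in this assay, within a range from 8 nM to 120 nM.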

Compound 4, half-maximal inhibitory concentration: 240 nM
Beside the measured number, compound 4's estimate is 8.0-fold (0.90 log units) below it; measured number above the stated range.
By their numbers in this assay, from the lowest: compound 3; then compounds 1 and 2 (each within the scatter of the next); then compound 4.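

In this assay the position proves not to be indifferent to what the nitrogen carries: dimethylamino and piperidin-1-yl could not be told apart, but bare amino falls clearly behind both (an 18-fold higher number from compound 2 to compound 4 (1.27 log units; beyond the scatter) and a 20-fold higher number from compound 1 to compound 4 (1.30 log units; beyond the scatter)). Across the whole series, the largest step lies between the bicyclic group and amino (a 240-fold higher number from compound 3 to compound 4 (2.38 log units; beyond the scatter)). The three substituted groups therefore all stand well clear of amino, although the bicyclic group still stands apart from the other two.

Amino both loses every carbon on the nitrogen and gains a hydrogen-bond donor, so these two changes cannot be separated here, and a methylamino group, which keeps a donor and carries one carbon, would bear on that question. Nothing measured here accounts for the size of the drop.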